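The compounds below may be only part of what the source reports. "The series", "measured", "known", "first", "only" and "open" are said of these compounds alone.

For the measured compounds named here, compound 3 `CC(=O)NC1CCC(CN2CCN(c3cc(=O)c4cc(C(F)(F)F)cc([N+](=O)[O-])c4s3)CC2)CC1` is one of three compounds measured in an ADME assay on Vero cells (Chlorocebus sabaeus) for cytotoxicity, read by MTT assay, with a stated time of 48 h; on this read-out higher numbers stand for weaker inhibition and lower numbers for stronger inhibition. In this assay compound 3 gives > 64 ug/mL, which is a limit of the assay and not a number. Compound 1 `O=c1cc(N2CCN(CC3CCC(OS(=O)(=O)c4cccnc4)CC3)CC2)sc2c([N+](=O)[O-])cc(C(F)(F)F)cc12` gives > 64 ug/mL in this assay, again a limit. Compound 2 `CS(=O)(=O)NC1CCC(CN2CCN(c3cc(=O)c4cc(C(F)(F)F)cc([N+](=O)[O-])c4s3)CC2)CC1` gives 48.5 ug/mL in this assay. Compound 3 therefore sits at the limit of > 64 ug/mL in this assay, at which 2 of the 3 values shown sit. The measured steps reaching it are an at least 1.3-fold higher number from compound 2 to compound 3 (0.12 log units; that floor lies within the scatter) and a step that the two limits leave unreadable from compound 1 to compound 3. Compound 4 `O=C(OC1CCC(CN2CCN(c3cc(=O)c4cc(C(F)(F)F)cc([N+](=O)[O-])c4s3)CC2)CC1)c1cccc(F)c1` differs from compound 3 by ((3-fluorophenyl)carbonyl)oxy in place of acetamido on a saturated ring carbon. Going by the values given here, no measured step exchanges acetamido for ((3-fluorophenyl)carbonyl)oxy on a saturated ring carbon, and no step beyond the scatter is expected in this assay. The value expected for compound 4 is estimated at 64 ug/mL, between 30 ug/mL and 128 ug/mL. That estimate amounts to an expected step of a number no higher from compound 3 to compound 4 (the limit leaves the size open).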

Compound 4, half-maximal inhibitory concentration: > 64 ug/mL
Compound 4: no number, only a limit; the forecaster's own chance of this, stated with the estimate: 55%; the middle value lies on the limit itself.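

In this assay, the ((3-fluorophenyl)carbonyl)oxy group, with its aromatic ring of carbon only, also leaves this saturated ring carbon at a limit and not a number: the limit of > 64 ug/mL in this assay, at which 3 of the 4 values shown sit. Exchanging methanesulfonamido for this group gives an at least 1.3-fold higher number from compound 2 to compound 4 (0.12 log units; that floor lies within the scatter), while the steps to compound 4 from compound 1 and compound 3 cannot be read. No step beyond the scatter therefore appears at this position in the compounds shown.

The limits leave any order among compound 1, compound 3 and compound 4 open. From the compounds shown here alone, whether a primary amine or a carboxylic acid on this ring carbon would give a lower number also remains open.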